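The source may hold more compounds than are shown below. What is called first, only, known or untested is meant among the compounds shown, and "the series" means these compounds.

Working notes on the series. The shared core carries a trimethoxyphenyl arm and a thioether-linked carbonyl, and the group on that carbonyl is what varies. Compound 1 `COc1cc(-c2nnc(SCC(=O)c3ccc(F)cc3)n2N)cc(OC)c1OC` gives 3230 nM in a functional assay on HCT-116 cells (Homo sapiens) for antiproliferative activity, read by MTT assay, with a stated time of 48 h (on this read-out higher numbers stand for weaker inhibition and lower numbers for stronger inhibition), which places it second highest of the three numbers measured: compound 3 `COc1ccc(C(=O)CSc2nnc(-c3cc(OC)c(OC)c(OC)c3)n2N)cc1` gives 1240 nM, and compound 2 `COc1cc(-c2nnc(SCC(=O)c3ccc(F)c(F)c3)n2N)cc(OC)c1OC` gives 10400 nM. The steps among them are modest but beyond the scatter: a 3.2-fold higher number from compound 1 to compound 2 (0.51 log units; beyond the scatter), a 2.6-fold lower number from compound 1 to compound 3 (0.42 log units; beyond the scatter) and an 8.4-fold lower number from compound 2 to compound 3 (0.92 log units; beyond the scatter).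

Compound 4 `COc1cc(-c2nnc(SCC(=O)NCc3ccc(C)cc3)n2N)cc(OC)c1OC` is not yet measured. It differs from compound 1 by (4-methylbenzyl)amino in place of 4-fluorophenyl on a carbonyl carbon. Among the measured compounds shown here, none of the measured steps swaps an aryl ketone for a benzylic amide; they only vary substituents on the aryl ring, and those moved the number by modest amounts in either direction. The change to compound 4 is larger in kind, so the expected step is uncertain and a somewhat higher number is taken as the central guess, with a wide range. Compound 4 is expected at 5000 nM (range 1500 nM to 17000 nM), meaning an expected 1.5-fold higher number from compound 1 to compound 4 (0.19 log units; within the scatter).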

Compound 4, half-maximal inhibitory concentration: > 100000 nM
Compound 4: no number, only a limit (the forecaster's own chance of this, stated with the estimate: 15%); middle value at least 20-fold (1.30 log units) away from the limit.
By their numbers in this assay, from the lowest: compound 3; then compound 1; then compound 2. At a limit, above all of these: compound 4.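

Compound 4 gives no number, only a limit: the limit of > 100000 nM in this assay, at which 1 of the 4 values shown sits.

On this carbonyl carbon, the earlier changes to the aryl group left the compounds with measurable numbers, whereas (4-methylbenzyl)amino gives an at least 30-fold higher number from compound 1 to compound 4 (1.49 log units; beyond the scatter), an at least 80-fold higher number from compound 3 to compound 4 (1.90 log units; beyond the scatter) and an at least 9.6-fold higher number from compound 2 to compound 4 (0.98 log units; beyond the scatter). The position therefore accommodates some variation on the aryl ketone in this assay, but this single benzylic amide shows that replacing the aryl group can abolish a measurable number at the concentrations covered.

The compounds shown leave open which part of the (4-methylbenzyl)amino group accounts for the change, as the amide nitrogen, the benzylic carbon and the methyl group all enter together. From the compounds shown here alone, whether a phenylamino or an unsubstituted benzylamino group on the same carbonyl carbon would restore a measurable number also remains open.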